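Shortening the pentyl chain of compound 1

The compounds below may be only part of what the source reports. "The series", "measured", "known", "first", "only" and "open" are said of these compounds alone.

Measured compounds:
compound 1 `CCCCCc1cc(-c2cn([C@H]3C[C@H](OC(C)=O)[C@@H](COC(C)=O)O3)c(=O)[nH]c2=O)on1`: 99.8%
compound 2 `CC(=O)OC[C@H]1O[C@@H](n2cc(-c3cn(Cc4ccc(C(C)C)cc4)nn3)c(=O)[nH]c2=O)C[C@@H]1OC(C)=O`: 92.2%

In a functional assay on ACHN cells (Homo sapiens) for cytotoxicity, read by sulforhodamine B assay, tested at 10 uM (on this read-out lower numbers stand for less inhibition and higher numbers for more inhibition at the one concentration tested (going by the name of the read-out)), compound 1 gives 99.8%, the higher of the two numbers on hand. Compound 2 gives 92.2%, a gap that lies within the scatter, so the two stand level. Compound 3 `CC(=O)OC[C@H]1O[C@@H](n2cc(-c3cc(C)no3)c(=O)[nH]c2=O)C[C@@H]1OC(C)=O` is not yet measured. It differs from compound 1 by hydrogen in place of butyl on a saturated chain carbon bound to an aromatic carbon, read one bond further out as 3-pentyl-1,2-oxazol-5-yl becoming 3-methyl-1,2-oxazol-5-yl. Within the data shown here, no step between measured compounds speaks to this change. A modest step downward is expected, a number 14.8 percentage points lower from compound 1 to compound 3 (beyond the scatter), because compound 1 sits at 99.8% and cannot rise further. Compound 3 is estimated at 85%, between 50% and 100%.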

Compound 3, a percentage reported as inhibition, at one concentration (the size of the read-out at that concentration, not a potency): 96.4%
The estimate for compound 3 lay 11.4 percentage points below the measured number, and the stated range covers the measured number.
By their numbers in this assay, from the lowest: compounds 2, 3 and 1 (each within the scatter of the next).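

In this assay, hydrogen in place of butyl on a saturated chain carbon bound to an aromatic carbon gives a number 3.4 percentage points lower from compound 1 to compound 3 (within the scatter). At this position, then, the pentyl chain can shrink to methyl without a step beyond the scatter, although both compounds sit close to the top of the scale, which leaves little room to see a difference. Nothing on hand accounts for this result. Still open, as far as these compounds go, is whether a chain longer than pentyl, or an amine or a carboxylic acid at the end of the chain, would leave the number unchanged. Also open, from the compounds shown here alone, is whether compound 1 and compound 3 would stay level at lower concentrations.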